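A few compounds are considered here, and "the series" means these few. Any claim that something is new, unique, unknown or untested is made for them only; others in the source may bear on it.

Of the compounds shown here, three sharing one core have been measured in a functional assay on KB cells (Homo sapiens) for inhibition; a lower number here means a stronger inhibitor, a higher number a weaker inhibitor. Compound 1 `Nc1nc2cc(Cl)c(Cl)cc2n1Cc1ccc(Cl)c(Cl)c1` gives 35000 nM, compound 2 `Nc1nc2cc(Cl)c(Cl)cc2n1Cc1cccc(Cl)c1` gives 65000 nM, and compound 3 `CC(C)(C)c1ccc(Cn2c(N)nc3cc(Cl)c(Cl)cc32)cc1` gives 50000 nM. These three values all lie within the scatter of one another, so compound 2 does not stand apart from the other two.

Compound 4 `Nc1nc2cc(Cl)c(Cl)cc2n1Cc1cccc(C(F)(F)F)c1` keeps the core of compound 2 and has trifluoromethyl in place of chloro on an aromatic carbon, meta to a large group (trifluoromethyl in place of chloro on an aromatic carbon). Among the compounds with values here, no measured compound here carries trifluoromethyl, so the evidence is indirect. The closest measured change also replaces a chloro on an aromatic carbon, though a different one and with hydrogen: a 1.9-fold higher number from compound 1 to compound 2 (0.27 log units; within the scatter). That small step, together with the close values of the three measured compounds, gives no reason to expect a large move in either direction. The step of a 1.3-fold lower number from compound 2 to compound 4 (0.11 log units; within the scatter) is therefore expected to remain within the scatter. For compound 4 the estimated value is 50000 nM, with an expected range from 25000 nM to 100000 nM.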

Compound 4, half-maximal inhibitory concentration: 45000 nM
Estimate against measurement, compound 4: 1.1-fold (0.05 log units) above; measured number inside the range.
By their numbers in this assay, from the lowest: compounds 1, 4, 3 and 2 (each within the scatter of the next).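

In this assay trifluoromethyl in place of chloro, on an aromatic carbon meta to a large group, gives a 1.4-fold lower number from compound 2 to compound 4 (0.16 log units; within the scatter) and so stays within the scatter. This is the first change shown at this position, and it swaps a single chlorine for a group of 4 heavy atoms, yet the read-out does not separate the two compounds. At this position, then, the assay tells chloro and trifluoromethyl apart no better than repeated measurements would, and no measured property of either group is available to explain the result.

As far as these compounds go, whether an amine, a carboxylic acid or a longer chain at this position would give a step beyond the scatter remains open. Also open, from the compounds shown here alone, is whether trifluoromethyl would give a similar result on the other carbons of this ring.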